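Exchanging the distal aryl group in a nitroarene series

The source may report more compounds than this note shows. Statements on the series, on what has been measured and on what is new or still open speak of the compounds shown alone.

Of the compounds shown here, three sharing one core have been measured in an ADME assay on HeLa Rh cells (Homo sapiens) for cytotoxicity, read by microscopy; on this read-out higher numbers stand for lower toxicity in this test and lower numbers for higher toxicity in this test. Compound 1 `COc1cc(CC(O)c2ccc(-c3ccc(C(F)(F)F)cc3)cc2)c([N+](=O)[O-])cc1OC` gives 4100 nM. Compound 2 `COc1cc(CC(O)c2ccc(-c3ccc(C)cc3)cc2)c([N+](=O)[O-])cc1OC` gives 4700 nM, and compound 3 `COc1cc(CC(O)c2ccc(-c3ccc(Cl)cc3)cc2)c([N+](=O)[O-])cc1OC` gives 4100 nM. The steps among them are small: a 1.1-fold higher number from compound 1 to compound 2 (0.06 log units; within the scatter), no change at the digits printed from compound 1 to compound 3 (within the scatter) and a 1.1-fold lower number from compound 2 to compound 3 (0.06 log units; within the scatter). Compound 2 thus has the highest of the three numbers, but its nearest neighbour, compound 1, and its furthest, compound 3, both sit within the scatter of it, so the three are not separated.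

Compound 4 `COc1cc(CC(O)c2ccc(-c3cccc(C#N)c3)cc2)c([N+](=O)[O-])cc1OC` is the next member. Relative to compound 2 the change is 3-cyanophenyl in place of 4-methylphenyl on an aromatic carbon. The three measured steps all bear on it, as each also exchanges the group on this aromatic carbon, and none of them moved the read-out beyond the scatter. Among the measured compounds shown here, the present change differs in that it also brings in a hydrogen-bond acceptor and shifts the substituent on the entering ring, for which no measured step exists. Since the earlier exchanges left this assay unchanged, the expected step is a 1.1-fold lower number from compound 2 to compound 4 (0.03 log units; within the scatter), that is, none beyond the scatter. Compound 4 is therefore estimated at 4400 nM, within a range from 2000 nM to 9500 nM.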

Compound 4, half-maximal cytotoxic concentration: 5200 nM
Compound 4: the middle estimate sits 1.2-fold (0.07 log units) below what was measured; measured number inside the range.
By their numbers in this assay, from the lowest: compounds 1, 3, 2 and 4 (each within the scatter of the next).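

In this assay the 3-cyanophenyl ring stays level with all three earlier aryl groups, with a 1.1-fold higher number from compound 2 to compound 4 (0.04 log units; within the scatter) and a 1.3-fold higher number from compound 3 to compound 4 (0.10 log units; within the scatter) and a 1.3-fold higher number from compound 1 to compound 4 (0.10 log units; within the scatter) all inside the scatter. The earlier steps shown here exchanged only the group on the 4-substituted ring, whereas this one brings in a nitrile and a hydrogen-bond acceptor and still leaves the read-out unseparated, so across these four compounds no exchange on this aromatic carbon, para to a large group, has moved the number beyond the scatter, and none of them goes against this. No measurement shown accounts for this flat result.

As far as these compounds go, whether the flatness holds for an amine or a carboxylic acid on the entering ring, or for a longer chain in place of the ring, remains open. Also open, from the compounds shown here alone, is how much of the number depends on the shared core, since its nitro group and its hydroxyl are the same in all four compounds and the effect of exchanging either cannot be read from them.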